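Fluorobenzyl triazole chalcones: growth inhibition working notes

This account rests on a few compounds, and the source may have more. Where it says the series, first, only, none or still open, it means among the compounds named here.

Measured in a functional assay on A549 cells (Homo sapiens) for inhibition, read by MTT assay, with a stated time of 48 h, tested at 10 uM (on this read-out lower numbers stand for less inhibition of growth and higher numbers for more inhibition of growth at the one concentration tested), so far:
compound 1 `O=C(/C=C/c1ccc(OCc2cn(Cc3cccc(F)c3)nn2)cc1)c1ccc(Br)cc1` gives 37%
compound 2 `O=C(/C=C/c1ccc(OCc2cn(Cc3ccc(F)cc3)nn2)cc1)c1ccc(Br)cc1` gives 43%
compound 3 `COc1ccc(C(=O)/C=C/c2ccc(OCc3cn(Cc4cccc(F)c4)nn3)cc2)cc1` gives 56%

Compound 1 and compound 2 differ by 4-fluorophenyl in place of 3-fluorophenyl on a saturated chain carbon bound to an aromatic nitrogen. This change gave a number 6 percentage points higher from compound 1 to compound 2 (within the scatter), so the two numbers cannot be told apart on this read-out.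

Compound 3 shares the triazole-linked chalcone with compound 1, but the cores differ by methoxy in place of bromo on an aromatic carbon. That change gave a number 19 percentage points higher from compound 1 to compound 3 (beyond the scatter), and compound 3 stands highest of the three measured numbers, with both gaps beyond the scatter.

Compound 4 `COc1ccc(C(=O)/C=C/c2ccc(OCc3cn(Cc4ccc(F)cc4)nn3)cc2)cc1` is the unmeasured partner of compound 3. The two differ by 4-fluorophenyl in place of 3-fluorophenyl on a saturated chain carbon bound to an aromatic nitrogen. The place is identical in wording to the earlier pair, so this is the same change as that from compound 1 to compound 2, now made on the core of compound 3.

The step for compound 4 is expected to be a number 4 percentage points higher from compound 3 to compound 4 (within the scatter) in this assay, resting on the single earlier occurrence, a number 6 percentage points higher from compound 1 to compound 2 (within the scatter), which lay within the scatter. Compound 4 is therefore estimated at 60%, with a range from 46% to 74%, around the value of compound 3, 56%.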

Compound 4, percent growth inhibition at one concentration: 33%
For compound 4 the middle estimate is 27 percentage points above the measured one; the measured number lies below the stated range.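

In this assay, the change from 3-fluorophenyl to 4-fluorophenyl does not carry from one core to the other, and on the methoxy core it gives a number 23 percentage points lower from compound 3 to compound 4 (beyond the scatter): the same change on two cores in this assay, a number 6 percentage points higher (within the scatter) from compound 1 to compound 2 and a number 23 percentage points lower (beyond the scatter) from compound 3 to compound 4, 29 percentage points apart, beyond the scatter of two such steps. The change from bromo to methoxy does not carry either, and on the 4-fluorobenzyl side it gives a number 10 percentage points lower from compound 2 to compound 4 (within the scatter): the same change on two cores in this assay, a number 19 percentage points higher (beyond the scatter) from compound 1 to compound 3 and a number 10 percentage points lower (within the scatter) from compound 2 to compound 4, 29 percentage points apart, beyond the scatter of two such steps. Within these four compounds, the result of each change therefore depends on the group at the other place, so a step from one core is a poor guide to the other; the data do not show why, and with only one pair per core they do not show how far this extends beyond these compounds.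

Still open, on these data alone, is whether this dependence recurs with a chloro, hydroxy or dimethylamino group on the aromatic carbon that carries bromo or methoxy. Also open, as far as these compounds go, is what an unsubstituted benzyl or a chlorobenzyl would give on the saturated chain carbon bound to the aromatic nitrogen of each core.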